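The source may hold more compounds than are shown below. What is called first, only, known or untested is meant among the compounds shown, and "the series" means these compounds.

In a functional assay on HeLa cells (Homo sapiens) for antiproliferative activity, read by MTT assay, with a stated time of 72 h (on this read-out higher numbers stand for weaker inhibition and lower numbers for stronger inhibition), compound 1 `O=c1c(SC(=S)N2CCCC2)coc2ccc(Cl)cc12` gives 16300 nM and compound 2 `CCOC(=O)c1cc(=O)c2cc(CSC(=S)N(C)c3ccccc3)ccc2o1` gives 18100 nM. Compound 3 `CC(C)N(C(=S)SCc1cc(=O)c2ccc(Cl)cc2o1)C(C)C` gives > 30000 nM, which is a limit of this assay rather than a measured number. From the compounds shown here alone, compound 3 sits at the limit of > 30000 nM in this assay, at which 1 of the 3 values shown sits, so its true potency is unknown. Compound 4 `O=c1cc(CSC(=S)N2CCOCC2)oc2cc(Cl)ccc12` has not yet been measured. It differs from compound 3 by morpholin-4-yl in place of diisopropylamino on a thiocarbonyl carbon. For the measured compounds named here, no two measured compounds differ in a single place, so no measured step guides this change. Compound 4 is expected to stay near the weak end, with an estimated step of an at least 1.2-fold lower number from compound 3 to compound 4 (0.07 log units; that floor lies within the scatter). The estimate for compound 4 in this assay is 25000 nM, within a range from 9000 nM to 60000 nM.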

Compound 4, half-maximal inhibitory concentration: 33300 nM
The estimate for compound 4 lay 1.3-fold (0.12 log units) below the measured number; low and high end bracket the measured number.
By their numbers in this assay, from the lowest: compounds 1, 2 and 4 (each within the scatter of the next, the first and the last beyond it).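

For the compounds shown here, no step from compound 3 to compound 4 can be read, because compound 3 stands only at a limit of the assay: the limit of > 30000 nM in this assay, at which 1 of the 4 values shown sits. The compounds shown leave open how far morpholin-4-yl in place of diisopropylamino moves the number.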